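This account rests on a few compounds, and the source may have more. Where it says the series, first, only, none or still open, it means among the compounds named here.

Compound 1 `Cc1cc(C(N)=O)nn1Cc1cc(Cl)ccc1OCc1ccccc1` gives 126 nM in an assay on CHO-K1 cells for displacement of a labelled ligand from prostaglandin E2 receptor EP1 subtype (Homo sapiens); a higher number here means a weaker inhibitor, a lower number a stronger inhibitor. Compound 2 `Cc1cc(C(=O)NC(C)C)nn1Cc1cc(Cl)ccc1OCc1ccccc1` gives 126 nM. Compound 3 `Cc1cc(C(=O)NCc2ccccc2)nn1Cc1cc(Cl)ccc1OCc1ccccc1` gives 39.8 nM.

Compound 3 holds the lowest of the three numbers, and its steps to the other two both lie beyond the scatter, whereas compounds 1 and 2 sit within the scatter of each other. Compound 4 `Cc1cc(C(=O)NCc2cccnc2)nn1Cc1cc(Cl)ccc1OCc1ccccc1` carries pyridin-3-yl in place of phenyl on a saturated chain carbon bound to an amide-type nitrogen. The measured steps all concern what sits on the amide-type nitrogen: a 3.2-fold lower number from compound 1 to compound 3 (0.50 log units; beyond the scatter) and a 3.2-fold lower number from compound 2 to compound 3 (0.50 log units; beyond the scatter), while no change at the digits printed from compound 1 to compound 2 (within the scatter). No measured step exchanges one aromatic ring for another on that benzyl group, so the phenyl-to-pyridin-3-yl swap has no direct precedent among these compounds. Because a 3.2-fold lower number from compound 1 to compound 3 (0.50 log units; beyond the scatter) came with the benzyl group as a whole, compound 4 is expected to stay near compound 3, with a 1.3-fold higher number from compound 3 to compound 4 (0.10 log units; within the scatter) judged to fall within the scatter. Compound 4 is therefore estimated at 50 nM, within 20 nM to 130 nM.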

Compound 4, half-maximal inhibitory concentration: 50.1 nM
For compound 4 the middle estimate is 1.0-fold (0.00 log units) below the measured one, within the range that was stated.
By their numbers in this assay, from the lowest: compounds 3 and 4 (each within the scatter of the next); then compounds 1 and 2 (each within the scatter of the next).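

Swapping the phenyl of the benzyl group for pyridin-3-yl, which adds a ring nitrogen and a hydrogen-bond acceptor, is tolerated at this place in this assay, with a 1.3-fold higher number from compound 3 to compound 4 (0.10 log units; within the scatter). The advantage over the primary and isopropyl amides persists, with a 2.5-fold lower number from compound 2 to compound 4 (0.40 log units; beyond the scatter) and a 2.5-fold lower number from compound 1 to compound 4 (0.40 log units; beyond the scatter), so in these compounds it does not require a ring of carbon only. No measured evidence bears on the reason for this result.

The compounds shown leave open whether a phenethyl group, with its longer chain, or an aromatic ring carrying an amine or a carboxylic acid would keep these numbers.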